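From compound 2 to compound 3: a 2,2,2-trichloroethyl swap

This account rests on a few compounds, and the source may have more. Where it says the series, first, only, none or still open, it means among the compounds named here.

In a physicochemical assay, read by HPLC, in phosphate buffer, with a stated time of 2 h, at pH 7.4 (on this read-out higher numbers stand for a more stable compound and lower numbers for a less stable compound), compound 1 `CC(C)C(=O)OCOC(=O)N1CCN(C(=O)c2nc(Nc3cc(C4CC4)[nH]n3)c3cc(Cl)ccc3n2)C[C@H]1C` gives 93.5% and compound 2 `CC(OC(=O)N1CCN(C(=O)c2nc(Nc3cc(C4CC4)[nH]n3)c3cc(Cl)ccc3n2)C[C@H]1C)OC(=O)C(C)(C)C` gives 90.5%, so these two compounds cannot be told apart. Among the compounds with values here, the one measured step, a number 3 percentage points lower from compound 1 to compound 2 (within the scatter), came from placing 1-(((tert-butyl)carbonyl)oxy)ethyl where ((isopropylcarbonyl)oxy)methyl had stood on an oxygen next to a carbonyl group.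

Compound 3 `C[C@@H]1CN(C(=O)c2nc(Nc3cc(C4CC4)[nH]n3)c3cc(Cl)ccc3n2)CCN1C(=O)OCC(Cl)(Cl)Cl` changes that same place again, with 2,2,2-trichloroethyl in place of 1-(((tert-butyl)carbonyl)oxy)ethyl on an oxygen next to a carbonyl group. This is a less close comparison, since neither measured compound carries the entering group, so the earlier step offers only indirect guidance. Even so, that step is the only evidence available, and it gives no reason to predict a real shift. The expected change is a number 2.5 percentage points higher from compound 2 to compound 3 (within the scatter), which is no step beyond the scatter. Compound 3 is estimated at 93%, within an expected range of 83% to 100%.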

Compound 3, percent of the compound remaining: 98.7%
Compound 3: middle estimate off by 5.7 percentage points, on the low side; low and high end bracket the measured number.
By their numbers in this assay, from the lowest: compounds 2, 1 and 3 (each within the scatter of the next).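

The position on an oxygen next to a carbonyl group also takes 2,2,2-trichloroethyl, a smaller group of 5 heavy atoms with chlorine and no oxygen, and this assay still cannot separate it from the two oxygen-bearing groups (a number 8.2 percentage points higher from compound 2 to compound 3 (within the scatter); a number 5.2 percentage points higher from compound 1 to compound 3 (within the scatter)). Within the data shown here, until now only two closely related groups, each carrying its own carbonyl, had been compared at this place, so the result widens the range of groups seen there without any change beyond the scatter. No measurement at hand explains the result or links it to any feature of the group.

Going by these compounds, whether every group at this place behaves alike remains open, since a plain ethyl group or a longer chain ending in an amine could read differently. The readings also cover only one pH and one stated time.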